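Moving the Chlorine Around the Amide Ring

This account rests on a few compounds, and the source may have more. Where it says the series, first, only, none or still open, it means among the compounds named here.

Two measured compounds share a common core and differ only in the ring on the carbonyl carbon of the amide. Compound 1 `O=C(Nc1ccc(Cl)c(-c2nnc3c(Cl)cccn23)c1)c1ccc(C(F)(F)F)cc1F` carries a ring bearing trifluoromethyl and fluorine there; in a functional assay on T47D cells (Homo sapiens) for antiproliferative activity, read by MTT assay, with a stated time of 72 h (on this read-out higher numbers stand for weaker inhibition and lower numbers for stronger inhibition), compound 1 gives 70800 nM. Compound 2 `O=C(Nc1ccc(Cl)c(-c2nnc3c(Cl)cccn23)c1)c1cccc(Cl)c1` carries a 3-chlorophenyl on that carbonyl; in this assay compound 2 gives 30200 nM. For the measured compounds named here, of the two numbers so far, compound 2 stands at the lowest, and its gap to compound 1 lies beyond the usual scatter, so compound 2 is the stronger inhibitor of this pair.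

Compound 3 `O=C(Nc1ccc(Cl)c(-c2nnc3c(Cl)cccn23)c1)c1ccc(Cl)cc1` has not been measured. It differs from compound 2 in a single way: 4-chlorophenyl in place of 3-chlorophenyl on a carbonyl carbon. The two have the same atoms, joined differently. Going by the values given here, no measured pair here isolates a change of this kind, so there is no step to lean on. Given that, the expected step in this assay is a 1.0-fold lower number from compound 2 to compound 3 (0.00 log units; within the scatter), that is, no change beyond the scatter in either direction. Compound 3 is therefore estimated at 30000 nM, with a range from 10000 nM to 90000 nM.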

Compound 3, half-maximal inhibitory concentration: > 100000 nM
Compound 3: a limit, no number (the forecaster's own chance of this, stated with the estimate: 15%); middle value at least 3.3-fold (0.52 log units) away from the limit.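

With the atoms unchanged and only the place of the chlorine altered, 4-chlorophenyl in place of 3-chlorophenyl on a carbonyl carbon whose other neighbour is an amide-type nitrogen gives an at least 3.3-fold higher number from compound 2 to compound 3 (0.51 log units; beyond the scatter) in this assay. The earlier pair, compound 1 and compound 2, differed in which groups the ring carried, so it could not show that this position responds to where a single chlorine sits, and not only to which groups are present. Compound 3 gives > 100000 nM in this assay, a limit of the assay and not a number, and the step is read against that limit: the limit of > 100000 nM in this assay, at which 1 of the 3 values shown sits.

The compounds shown leave open how far the true value of compound 3 lies past that limit, and they give no reason why the place of the chlorine matters here. Also open, going by these compounds, is whether a methoxy group or an amine in place of the chlorine of 3-chlorophenyl would keep, improve or lose the inhibition seen with compound 2.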